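Amide nitrogen substituent and permeability: compound 3 to compound 4

The source may report more compounds than this note shows. Statements on the series, on what has been measured and on what is new or still open speak of the compounds shown alone.

Of the compounds shown here, three of a shared core have been measured in an ADME assay for permeability; a lower number here means that the compound crosses the layer more slowly, a higher number that the compound crosses the layer faster. Compound 1 `CCNC(=O)c1cc(C(=O)NC)nn1[C@@H](C)c1ccccc1` gives 435 nm/s. Compound 2 `CCCNC(=O)c1cc(C(=O)NC)nn1[C@@H](C)c1ccccc1` gives 560 nm/s. Compound 3 `CNC(=O)c1cc(C(=O)N[C@H]2[C@@H]3C[C@@H](OC)C[C@@H]32)n([C@@H](C)c2ccccc2)n1` gives 440 nm/s. On these numbers compound 3 stands close to both of the others: the step is a 1.0-fold higher number from compound 1 to compound 3 (0.00 log units; within the scatter) and a 1.3-fold lower number from compound 2 to compound 3 (0.10 log units; within the scatter), so neither gap counts as a real difference. The remaining comparison, a 1.3-fold higher number from compound 1 to compound 2 (0.11 log units; within the scatter), is within the scatter as well.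

Compound 4 `CNC(=O)c1cc(C(=O)NC)n([C@@H](C)c2ccccc2)n1` is the next compound to be measured. one carbon atom in place of a group of 8 heavy atoms (7 carbon, 1 oxygen; one three-membered non-aromatic ring of carbon only, one five-membered non-aromatic ring of carbon only), on an amide-type nitrogen All three measured steps alter the group on the same amide-type nitrogen and so bear on this change. Each of them stayed within the scatter, whether the group was lengthened by a carbon, enlarged to the bicyclic group, or exchanged from the two-carbon or three-carbon chain to that group. Cutting the group back to methyl is therefore not expected to move this assay beyond the scatter in either direction; the expected step for compound 4 is a 1.0-fold higher number from compound 3 to compound 4 (0.01 log units; within the scatter). Compound 4 is expected to give 450 nm/s, with a range from 300 nm/s to 680 nm/s.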

Compound 4, apparent permeability in the ADME assay: 280 nm/s
For compound 4 the middle estimate is 1.6-fold (0.21 log units) above the measured one, and the stated range ends above it.
By their numbers in the ADME assay, from the lowest: compounds 4, 1, 3 and 2 (each within the scatter of the next).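

Cutting the group on this amide-type nitrogen back to methyl still gives no step beyond the scatter in the ADME assay, whether compound 4 is set against the bicyclic group (a 1.6-fold lower number from compound 3 to compound 4 (0.20 log units; within the scatter)), the ethyl-bearing compound (a 1.6-fold lower number from compound 1 to compound 4 (0.19 log units; within the scatter)) or the compound with the three-carbon chain (a 2.0-fold lower number from compound 2 to compound 4 (0.30 log units; within the scatter)). The last of these is the largest step in the set and is still printed as within the scatter, so methyl, the two chains and the group of 8 heavy atoms cannot be told apart at this position, and the earlier compounds had not shown this for a group as short as methyl. The same exchange also stays within the scatter in a physicochemical assay for lipophilicity (a lower number here means a more polar compound, a higher number a more lipophilic compound), where compound 3 gives (2.7) and compound 4 gives (3), with the step printed as (a number 0.30 log units higher from compound 3 to compound 4 (within the scatter)).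

On these data alone, whether a longer chain, an amine or a carboxylic acid on this nitrogen would move either read-out beyond the scatter remains open. Nothing available explains the numbers at this position.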